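The source may report more compounds than this note shows. Statements on the series, on what has been measured and on what is new or still open speak of the compounds shown alone.

Notes on the series. Compound 1 `COC(=O)C1=C(C)NC(=O)NC1c1cccc([N+](=O)[O-])c1` gives 18900 nM in an assay on HEK293 cells for antagonist activity at Voltage-dependent L-type calcium channel subunit alpha-1D (Rattus norvegicus), read by FLIPR; a higher number here means a weaker inhibitor, a lower number a stronger inhibitor. Compound 2 `COC(=O)C1=C(C(C)C)NC(=O)NC1c1cccc([N+](=O)[O-])c1` carries an isopropyl in place of the methyl on a double-bonded ring carbon; in this assay compound 2 reaches only the limit > 100000 nM. The step of an at least 5.2-fold higher number from compound 1 to compound 2 (0.72 log units; beyond the scatter) thus places compound 2 at the weak end of the numbers seen so far, at the limit of > 100000 nM in this assay, at which 1 of the 3 values shown sits. Compound 3 `CC1=C(C(=O)OC(C)C)C(c2cccc([N+](=O)[O-])c2)N(C(=O)C(C)C)C(=O)N1`, which differs from both in several places, gives 990 nM in this assay.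

Compound 4 `COC(=O)C1=C(C(C)C)NC(=O)N(C(=O)OC(C)C)C1c1cccc([N+](=O)[O-])c1` is reached from compound 2 by a single change: isopropoxycarbonyl in place of hydrogen on an amide-type nitrogen in a ring. The new group enters on the amide-type nitrogen next to the ring atom that bears the 3-nitrophenyl group. Among the measured compounds shown here, no measured step covers this exact substitution; the only step that bears on compound 4 is the one that fixes its starting point, from compound 1 to compound 2, which was at least modest and went toward a weaker inhibitor. The values of compound 1 and compound 3 show that a compound acylated on this ring nitrogen, with other changes alongside, sits well below the unsubstituted parent, so some gain from a carbonyl-bearing group on the nitrogen is expected. Compound 4 is therefore expected to come in at 30000 nM, between 5000 nM and 150000 nM, a step of an at least 3.3-fold lower number from compound 2 to compound 4 (0.52 log units; beyond the scatter) if compound 2 is taken at its limit.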

Compound 4, half-maximal inhibitory concentration: 10100 nM
Estimate against measurement, compound 4: 3.0-fold (0.47 log units) above; the range from low to high includes it.
By their numbers in this assay, from the lowest: compound 3; then compounds 4 and 1 (each within the scatter of the next). At a limit, above all of these: compound 2.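

On the amide-type nitrogen in the ring, next to the ring atom that bears a 3-nitrophenyl group, isopropoxycarbonyl in place of hydrogen gives an at least 9.9-fold lower number from compound 2 to compound 4 (0.99 log units; beyond the scatter) in this assay and is the first single change shown that moves toward a stronger inhibitor. Among the compounds shown here, compound 3 also carries a carbonyl-bearing group on a ring nitrogen, but with other changes alongside, so only this step ties a gain to substitution at this nitrogen, and it shows that a group of 6 heavy atoms with no hydrogen-bond donor can replace the hydrogen there without loss. Compound 2 at > 100000 nM stands at a limit of the assay, so the step has a lower bound only.

From the compounds shown here alone, whether an acetyl, an ester with a longer chain or a chain ending in an amine on this nitrogen would give a step of similar size remains open. Also open, going by these compounds, is whether isopropoxycarbonyl brings a similar step on the core of compound 1, which has methyl in place of the isopropyl.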